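The source may hold more compounds than are shown below. What is called first, only, known or untested is meant among the compounds shown, and "the series" means these compounds.

Measured so far:
- compound 1, `Nc1ccccc1NC(=O)c1ccc(COc2ccccc2)cc1`: 4890 nM
- compound 2, `CCc1ccc(OCc2ccc(C(=O)Nc3ccccc3N)cc2)cc1`: 4830 nM

In a functional assay on HCT-116 cells (Homo sapiens) for antiproliferative activity, read by CCK-8 assay, with a stated time of 72 h (on this read-out higher numbers stand for weaker inhibition and lower numbers for stronger inhibition), compound 1 gives 4890 nM. Compound 2 gives 4830 nM. Among the measured compounds shown here, of the two numbers in hand, compound 1 stands uppermost, yet the single step between them, a 1.0-fold lower number from compound 1 to compound 2 (0.01 log units; within the scatter), does not reach beyond the scatter; an ethyl in place of hydrogen on the outer aromatic ring left the read-out where it was.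

Compound 3, `Nc1ccccc1NC(=O)c1ccc(COc2ccc(F)cc2)cc1`, is not yet measured. Against compound 1 the difference is fluoro in place of hydrogen on an aromatic carbon. For the measured compounds named here, the one measured step that bears on this change is the same exchange of hydrogen at the same aromatic carbon, which gave a 1.0-fold lower number from compound 1 to compound 2 (0.01 log units; within the scatter). That step was flat, and a fluoro atom is the smaller of the two entering groups, so no step beyond the scatter is expected in this assay for compound 3 either, in neither direction. Compound 3 is therefore estimated at 4600 nM, with a range from 2200 nM to 9500 nM. The expected step is a 1.1-fold lower number from compound 1 to compound 3 (0.03 log units; within the scatter).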

Compound 3, half-maximal inhibitory concentration: 3860 nM
Compound 3: the middle estimate sits 1.2-fold (0.08 log units) above what was measured; the measured number falls inside the stated range.
By their numbers in this assay, from the lowest: compounds 3, 2 and 1 (each within the scatter of the next).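

In this assay, the aromatic carbon para to a large group in the phenoxy group now carries hydrogen, ethyl or fluoro without any step beyond the scatter: fluoro in place of hydrogen gives (a 1.3-fold lower number from compound 1 to compound 3 (0.10 log units; within the scatter)), and fluoro in place of ethyl gives (a 1.3-fold lower number from compound 2 to compound 3 (0.10 log units; within the scatter)). The flat reading at this carbon therefore no longer rests on ethyl alone, since a second and different group, a single fluorine atom, also leaves all three compounds within the scatter of one another. Nothing in hand explains this flat reading.

From the compounds shown here alone, whether an amine, a carboxylic acid, a methoxy group or a longer chain on this same carbon would produce a step beyond the scatter remains open, as the three compounds cover only hydrogen, ethyl and fluoro. Also open, going by these compounds, is whether fluoro on another carbon of the phenoxy group, or a change elsewhere in the shared core, would move the number in this cell assay, as all three compounds differ only at this one carbon.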